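Notes on replacing the 4-bromophenyl group of compound 1

This account rests on a few compounds, and the source may have more. Where it says the series, first, only, none or still open, it means among the compounds named here.

Compound 1 `O=C(Nc1ccc(F)cc1)N1N=C(c2ccc(Br)cc2)CC1c1ccc(F)cc1` gives 16 nM in an assay on HEK293 cells for inhibition of Voltage-dependent T-type calcium channel subunit alpha-1H (Homo sapiens), read by FLIPR and calcium flux, with a stated time of 3 min (on this read-out lower numbers stand for stronger inhibition and higher numbers for weaker inhibition), the lowest of the three numbers recorded in the set. Compound 2 `COc1ccc(NC(=O)N2N=C(c3ccc(Br)cc3)CC2c2ccc(F)cc2)cc1` gives 447 nM, a step of a 28-fold higher number from compound 1 to compound 2 (1.45 log units; beyond the scatter), and compound 3 `CC(C)NC(=O)N1N=C(c2ccc(Br)cc2)CC1c1ccc(F)cc1` gives 382 nM, a step of a 24-fold higher number from compound 1 to compound 3 (1.38 log units; beyond the scatter); between those two a 1.2-fold lower number from compound 2 to compound 3 (0.07 log units; within the scatter). Compound 4 `O=C(Nc1ccc(F)cc1)N1N=C(c2cc[n+]([O-])cc2)CC1c1ccc(F)cc1` alters a different part of the shared core: a group of 7 heavy atoms (5 carbon, 1 nitrogen, 1 oxygen; one six-membered aromatic ring with 1 hetero atom) in place of a group of 7 heavy atoms (6 carbon, 1 bromine; one six-membered aromatic ring of carbon only), on a carbon with a double bond to nitrogen. Among the measured compounds shown here, no measured step touches this carbon, so neither large step bears directly on the change; they show only that single alterations elsewhere in compound 1 cost a great deal. The step is therefore estimated as a 16-fold higher number from compound 1 to compound 4 (1.19 log units; beyond the scatter), a weaker expected result with wide uncertainty. Compound 4 is estimated at 250 nM, expected between 50 nM and 1200 nM.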

Compound 4, half-maximal inhibitory concentration: 110 nM
Beside the measured number, compound 4's estimate is 2.3-fold (0.36 log units) above it; the measured number falls inside the stated range.
By their numbers in this assay, from the lowest: compound 1; then compound 4; then compounds 3 and 2 (each within the scatter of the next).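

Among the compounds shown here, this is the first measured change at the carbon with a double bond to nitrogen, and it gives a 6.9-fold higher number from compound 1 to compound 4 (0.84 log units; beyond the scatter). Activity therefore depends on the group at this carbon, although the 4-bromophenyl group can be exchanged for an aromatic ring with a hetero atom and an added oxygen while a measurable inhibition remains. Nothing available explains this loss.

The compounds shown do not separate removal of the bromine from entry of the ring nitrogen and its oxygen. A plain phenyl group or a pyridine ring without the oxygen at this carbon would bear on that.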